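Chloro for Fluoro on a Shared Core

The source may hold more compounds than are shown below. What is called first, only, known or untested is meant among the compounds shown, and "the series" means these compounds.

Measured compounds:
compound 1, `CC(C)NS(=O)(=O)Cc1noc2ccc(F)cc12`: 38 mg/kg
compound 2, `CN(C)S(=O)(=O)Cc1noc2ccc(F)cc12`: 32 mg/kg

Among the compounds with values here, compound 1 has the highest of the two numbers in a functional assay on the whole organism (strain STD-dd) with Mus musculus as the target, in the maximal electroshock model, with a stated time of 2 h (a higher number here means that more compound is needed for the effect, a lower number that less compound is needed), but the single step, a 1.2-fold lower number from compound 1 to compound 2 (0.07 log units; within the scatter), lies within the scatter, so the two compounds cannot be told apart on dose for half-maximal effect. Compound 3, `CC(C)NS(=O)(=O)Cc1noc2ccc(Cl)cc12`, differs from compound 1 by chloro in place of fluoro on an aromatic carbon. Within the data shown here, no measured step touches this ring position: the one step recorded, from compound 1 to compound 2, alters the amine on the sulfonyl sulfur, not the halogen, and it was within the scatter anyway. With nothing to point either way, compound 3 is expected to stay close to compound 1, with the step of a 1.1-fold lower number from compound 1 to compound 3 (0.04 log units; within the scatter) expected to fall within the scatter. The estimate for compound 3 in this assay is 35 mg/kg, with a range from 17 mg/kg to 70 mg/kg.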

Compound 3, dose for half-maximal effect: 100 mg/kg
Compound 3: the middle estimate sits 2.9-fold (0.46 log units) below what was measured; measured number above the stated range.
By their numbers in this assay, from the lowest: compounds 2 and 1 (each within the scatter of the next); then compound 3.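

In this assay, the halogen on this aromatic carbon separates two compounds, which the earlier step on the sulfonyl sulfur did not do (a 1.2-fold lower number from compound 1 to compound 2 (0.07 log units; within the scatter)). Chloro in place of fluoro (a 2.6-fold higher number from compound 1 to compound 3 (0.42 log units; beyond the scatter)) is a modest change but lies beyond the scatter, and it goes towards more compound being needed for the effect. Nothing at hand bears on why this exchange of one halogen for another shifts the number.

On these data alone, it remains open whether fluoro or chloro is the exception at this position, which a hydrogen, a methyl or a methoxy group on the same carbon could help to settle. As far as these compounds go, it also remains open whether chloro in place of fluoro gives a similar step with dimethylamino on the sulfonyl sulfur.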